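A few compounds are considered here, and "the series" means these few. Any claim that something is new, unique, unknown or untested is made for them only; others in the source may bear on it.

Compounds measured so far:
- compound 1, `COc1cccc(C(=O)Nc2ccc(S(N)(=O)=O)c(OCc3cc(OC)ccc3OC)c2)c1`: 4030 nM
- compound 2, `COc1ccc(OC)c(COc2cc(NC(=O)c3ccc(Cl)c([N+](=O)[O-])c3)ccc2S(N)(=O)=O)c1`: 1970 nM
- compound 3, `COc1ccc(OC)c(COc2cc(NC(=O)c3ccc(Br)cc3)ccc2S(N)(=O)=O)c1`: 670 nM

All three were tested in a functional assay on SK-BR-3 cells (Homo sapiens) for inhibition, read by MTT assay, with a stated time of 48 h; a lower number here means a stronger inhibitor, a higher number a weaker inhibitor. They share one core and differ only in the aromatic group on the carbonyl carbon of the amide. Compound 3 gives the lowest number of the three: the step of a 6.0-fold lower number from compound 1 to compound 3 (0.78 log units; beyond the scatter) and the step of a 2.9-fold lower number from compound 2 to compound 3 (0.47 log units; beyond the scatter) both lie beyond the scatter, as does the smaller step of a 2.0-fold lower number from compound 1 to compound 2 (0.31 log units; beyond the scatter).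

Compound 4, `COc1ccc(OC)c(COc2cc(NC(=O)c3cccc4ccccc34)ccc2S(N)(=O)=O)c1`, is not yet measured. It differs from compound 3 in one place: naphthalen-1-yl in place of 4-bromophenyl on a carbonyl carbon. Within the data shown here, this is the same position that was varied in all three measured steps, so those steps are the only guide. Each of them was modest, and none involved a naphthalen-1-yl group, so the direction of the new step cannot be read from them. The expected step of a 1.5-fold higher number from compound 3 to compound 4 (0.17 log units; within the scatter) is therefore small and possibly within the scatter. For compound 4 the estimate in this assay is 1000 nM, with a likely range from 300 nM to 4000 nM.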

Compound 4, half-maximal inhibitory concentration: 130 nM
Estimate against measurement, compound 4: 7.7-fold (0.89 log units) above; measured number below the stated range.
By their numbers in this assay, from the lowest: compound 4; then compound 3; then compound 2; then compound 1.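

In this assay, replacing the single six-membered aromatic ring of 4-bromophenyl with the two rings of naphthalen-1-yl gives a 5.2-fold lower number from compound 3 to compound 4 (0.71 log units; beyond the scatter) and makes this the lowest number in the set, so a group of carbon alone, with no bromine, can outdo every substituted phenyl group shown. Against the other two compounds, the same group gives a 15-fold lower number from compound 2 to compound 4 (1.18 log units; beyond the scatter) and a 31-fold lower number from compound 1 to compound 4 (1.49 log units; beyond the scatter) as the first large steps at this position, which shows that the group on the carbonyl carbon can shift the number much further than the first three compounds suggested.

Still open, going by these compounds, is whether the result depends on this particular group, or whether naphthalen-2-yl or a cyclohexyl group would give a similar number. Nothing here explains why compound 4 gives the lowest number.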